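Chain substitution on a diaryl lignan-type scaffold in HL-60

A few compounds are considered here, and "the series" means these few. Any claim that something is new, unique, unknown or untested is made for them only; others in the source may bear on it.

Two compounds of this series carry numbers in a functional assay on HL-60 cells (Homo sapiens) for cytotoxicity, read by WST assay, with a stated time of 48 h; a higher number here means a weaker inhibitor, a lower number a stronger inhibitor. Compound 1 `COc1ccc(C(c2ccc(OC)c(OC)c2)[C@@H](C)[C@H](C)CO)cc1OC` reaches only the limit of this assay, giving > 100000 nM, which is a limit and not a measurement. For the measured compounds named here, compound 2 `COc1cc(C(c2ccc(O)c(OC)c2)[C@H](CF)C(C)C)ccc1O` is the only member with a definite number: in this assay compound 2 gives 19000 nM. Going by the values given here, with one value sitting at the limit of > 100000 nM in this assay, at which 1 of the 2 values shown sits, and the other the sole figure, no step between measured compounds can be read, so compound 2 stands alone as the reference point.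

Compound 3 `CCCCC[C@H](C(C)C)C(c1ccc(O)c(OC)c1)c1ccc(O)c(OC)c1` is yet to be tested in this assay. It differs from compound 2 in one place: butyl in place of fluoro on a saturated chain carbon, three bonds along the chain from two aromatic carbons. Cut one bond further out, the change reads fluoromethyl to pentyl on that saturated chain carbon. No measured step covers this kind of exchange, so the size and direction of its effect cannot be taken from the data shown.

The expectation for compound 3 is a moderate gain, a step of a 2.4-fold lower number from compound 2 to compound 3 (0.38 log units; beyond the scatter) that only just passes beyond the usual scatter. Compound 3 is thus estimated at 8000 nM, within a range from 2000 nM to 40000 nM.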

Compound 3, half-maximal inhibitory concentration: 9600 nM
Compound 3: middle estimate off by 1.2-fold (0.08 log units), on the low side; the range from low to high includes it.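

In this assay, the exchange of fluoro for butyl on a saturated chain carbon, three bonds along the chain from two aromatic carbons, gives a 2.0-fold lower number from compound 2 to compound 3 (0.30 log units; within the scatter). For the compounds shown here, this is the first step that can be read, and it shows that at this position the exchange of fluoromethyl for pentyl leaves compound 3 and compound 2 within the scatter of each other, so the fluoro is not required for a definite number in this assay, and a longer saturated chain is carried there with no distinguishable difference. Steps to compound 1 cannot be read, as its value is a limit and it differs from the others in more than one place: the limit of > 100000 nM in this assay, at which 1 of the 3 values shown sits.

Open, as far as these compounds go, is whether an amine, a carboxylic acid or a chain longer than pentyl on this same carbon would move the number beyond the scatter in either direction. Also open, from the compounds shown here alone, is whether a phenyl group there would separate from compound 2 and compound 3, since one readable step gives no trend along this position.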